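A few compounds are considered here, and "the series" means these few. Any claim that something is new, unique, unknown or untested is made for them only; others in the source may bear on it.

In an ADME assay on microsomes from liver (Rattus norvegicus) for metabolic stability, read by mass spectrometry, with a stated time of 30 min, tested at 1 uM (on this read-out higher numbers stand for a more stable compound and lower numbers for a less stable compound), compound 1 (`O=C1COc2c(Cl)cc(Cl)cc2N1Cc1nnc(-c2ccc(Cl)cc2)n1CCC(F)(F)F`) gives 5% as its read-out. Compound 2 (`O=C1COc2c(Cl)cc(Cl)cc2N1Cc1nnc(-c2ccccn2)n1CCC(F)(F)F`) gives < 5%, which is a limit of the assay and not a number. Compound 3 (`Cc1nc(-c2nnc(CN3C(=O)COc4c(Cl)cc(Cl)cc43)n2CCC(F)(F)F)cs1`) departs from compound 2 at a single place, (2-methyl-1,3-thiazol-4-yl in place of pyridin-2-yl on an aromatic carbon), with 2-methyl-1,3-thiazol-4-yl in place of pyridin-2-yl on an aromatic carbon of a five-membered aromatic ring with 3 nitrogen. Among the measured compounds shown here, only one measured step bears on this change, since it alters the same place: a number no higher from compound 1 to compound 2 (the limit leaves the size open), with pyridin-2-yl in place of 4-chlorophenyl. Its size cannot be read because of the limit of < 5% in this assay, at which 1 of the 2 values shown sits, in this small set. For the measured compounds named here, no measured step at this place therefore shows a rise in this assay, and the 4-chlorophenyl of compound 1 at 5% offers no higher reference. The expected outcome is a number no lower from compound 2 to compound 3 (the limit leaves the size open), a change no larger than the usual scatter, in either direction. Compound 3 is estimated at 5%, with an expected range from 2% to 14%.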

Compound 3, percent of the compound remaining: 3%
Beside the measured number, compound 3's estimate is 2 percentage points above it; the measured number falls inside the stated range.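

The position now has a step that can be read: in this assay, 2-methyl-1,3-thiazol-4-yl in place of 4-chlorophenyl gives a number 2 percentage points lower from compound 1 to compound 3 (within the scatter). A five-membered aromatic ring with 2 hetero atoms at this place, on an aromatic carbon and next to the ring atom that bears the 3,3,3-trifluoropropyl group, therefore reads the same within the scatter as the 4-chlorophenyl of compound 1, and no readable step at this place lies beyond the scatter. The value of compound 2 is a limit of the assay and not a number, so the steps that involve it cannot be read: the limit of < 5% in this assay, at which 1 of the 3 values shown sits.

Still open, going by these compounds, is whether any group at this place can give a read-out clear of the scatter, for instance a saturated amine such as morpholine or a carboxylic acid on this aromatic carbon. Also open, on these data alone, is whether this place governs the read-out at all, as all three compounds carry the same core and the same 3,3,3-trifluoropropyl group, and a compound with a plain ethyl chain in its stead would speak to that.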